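Swapping an isopropyl for a 4-bromobenzyl on the amine

This account rests on a few compounds, and the source may have more. Where it says the series, first, only, none or still open, it means among the compounds named here.

Compound 1 `COc1cc(Oc2cccc(Nc3ccccc3)c2)cc(OC)c1CNCCNC(C)=O`: 11900 nM
Compound 2 `COc1cc(Oc2cccc(Nc3ccccc3)c2)cc(OC)c1CNC(C)C`: > 20000 nM

In a functional assay on SW-620 cells (Homo sapiens) for inhibition, read by MTT assay, with a stated time of 72 h (on this read-out higher numbers stand for weaker inhibition and lower numbers for stronger inhibition), compound 1 gives 11900 nM. Compound 2 reaches only the limit of this assay, > 20000 nM, so it stands at the weak end of what was measured. Among the measured compounds shown here, the one measured step, an at least 1.6-fold higher number from compound 1 to compound 2 (0.22 log units; that floor lies within the scatter), concerns a different change and gives no guide to a benzyl group. Compound 3 `COc1cc(Oc2cccc(Nc3ccccc3)c2)cc(OC)c1CNCc1ccc(Br)cc1` differs from compound 2 by 4-bromobenzyl in place of isopropyl on an amine nitrogen. For the measured compounds named here, with no comparable step, the expected change is an at least 1.3-fold lower number from compound 2 to compound 3 (0.12 log units; that floor lies within the scatter), and compound 3 is estimated at 15000 nM, between 4000 nM and 40000 nM.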

Compound 3, half-maximal inhibitory concentration: 11200 nM
The estimate for compound 3 lay 1.3-fold (0.13 log units) above the measured number; the measured number falls inside the stated range.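

Compound 2 gives no exact number, only a limit of the assay: the limit of > 20000 nM in this assay, at which 1 of the 3 values shown sits.

Putting 4-bromobenzyl on the amine nitrogen yields a measurable number in this assay, with an at least 1.7-fold lower number from compound 2 to compound 3 (0.25 log units; that floor lies within the scatter), so even this floor does not establish a real gain. The 4-bromobenzyl and 2-acetamidoethyl groups cannot be told apart here, with a 1.1-fold lower number from compound 1 to compound 3 (0.03 log units; within the scatter). From the compounds shown here alone, whether a plain benzyl without the bromine, or a chain ending in a carboxylic acid, would give a clearly lower number on this nitrogen stays open.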